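Phenyl in place of isopropyl in compound 3

The source may report more compounds than this note shows. Statements on the series, on what has been measured and on what is new or still open speak of the compounds shown alone.

Numbers so far in a functional assay for inhibition, with Rattus norvegicus as the target, at pH 7.35 (a higher number here means a weaker inhibitor, a lower number a stronger inhibitor), are these:

- compound 1 `CCCCOC(=O)C(=O)C(CC)NC(=O)C(CC(C)C)NC(=O)OCc1ccccc1` gives 28000 nM
- compound 2 `CCC(=O)C(=O)[C@H](CC)NC(=O)[C@H](CC(C)C)NC(=O)[C@H](CC(C)C)NC(=O)OCc1ccccc1` gives 40000 nM
- compound 3 `CCC(NC(=O)C(CC(C)C)NC(=O)OCc1ccccc1)C(=O)C(=O)NCC(C)C` gives 28000 nM

Compound 3 stands level with compound 1, and compound 2 lies within the scatter of it, so the three numbers form a single level. Compound 4 `CCC(NC(=O)C(CC(C)C)NC(=O)OCc1ccccc1)C(=O)C(=O)NCc1ccccc1` has phenyl in place of isopropyl on a saturated chain carbon bound to an amide-type nitrogen, which turns isobutylamino into benzylamino (phenyl in place of isopropyl on a saturated chain carbon bound to an amide-type nitrogen). Going by the values given here, one measured step bears on this change. It placed isobutylamino in place of butoxy on a carbonyl carbon, and the number did not move: no change at the digits printed from compound 1 to compound 3 (within the scatter). Among the compounds with values here, that is only one step, and no measured compound carries a ring on this amide nitrogen, so the direction stays open. The expected result is no change beyond the scatter, a 1.1-fold lower number from compound 3 to compound 4 (0.05 log units; within the scatter). For compound 4 the estimate is 25000 nM, with an expected range from 10000 nM to 60000 nM.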

Compound 4, half-maximal inhibitory concentration: 50000 nM
Beside the measured number, compound 4's estimate is 2.0-fold (0.30 log units) below it; the range from low to high includes it.
By their numbers in this assay, from the lowest: compounds 1, 3, 2 and 4 (each within the scatter of the next).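

In this assay, the first aromatic ring on this amide nitrogen, phenyl in place of isopropyl on a saturated chain carbon, gives a 1.8-fold higher number from compound 3 to compound 4 (0.25 log units; within the scatter). Comparing the same benzylamino group with the butoxy group on a carbonyl carbon gives a 1.8-fold higher number from compound 1 to compound 4 (0.25 log units; within the scatter), so neither step separates compound 4 from the compound it is measured against. No measurement given here accounts for this result.

Still open, going by these compounds, is whether a longer chain between the nitrogen and the phenyl ring, as in phenethylamino, would give a step beyond the scatter. The same question stands for a benzyl group carrying an amine or a carboxylic acid on its ring.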